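Swapping Fluoro for Methoxy: An Expected Clearance for Compound 4

The compounds below may be only part of what the source reports. "The series", "measured", "known", "first", "only" and "open" are said of these compounds alone.

Measured so far in an ADME assay on microsomes from liver (Homo sapiens) for metabolic stability, tested at 2.5 uM; a lower number here means slower removal, a higher number faster removal of the compound:
Compound 1, `COc1cccc(-c2c(S(=O)(=O)c3ccc(OC)c(Cl)c3)cnc3cc(F)ccc23)c1`, gives 1.71 mL/min.
Compound 2, `O=S(=O)(c1cc(Cl)cc(Cl)c1)c1cnc2c(F)cccc2c1-c1ccc(F)cc1`, gives 1.01 mL/min.
Compound 3, `COc1ccc(S(=O)(=O)c2cnc3cc(F)ccc3c2-c2cccc(F)c2)cc1Cl`, gives 2.08 mL/min.

Compound 3 and compound 1 differ in one place only: methoxy in place of fluoro on an aromatic carbon. That change produced a 1.2-fold lower number from compound 3 to compound 1 (0.09 log units; within the scatter), so the two cannot be told apart by this assay. Compound 2 shows the lowest of the three numbers, but its gap to compound 1 is within the scatter and only its gap to compound 3 lies beyond it. The difference between the cores of compound 2 and compound 3 is not broken down here.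

Compound 4, `COc1ccc(-c2c(S(=O)(=O)c3cc(Cl)cc(Cl)c3)cnc3c(F)cccc23)cc1`, has not been measured yet. It arises from compound 2 by methoxy in place of fluoro on an aromatic carbon. In compound 3 and compound 1 the change sits meta to a large group, whereas in compound 2 and compound 4 it sits para to a large group, so this is the same kind of change, not the same.

In this assay the step is estimated at a 1.1-fold lower number from compound 2 to compound 4 (0.05 log units; within the scatter), because the same kind of change gave a 1.2-fold lower number from compound 3 to compound 1 (0.09 log units; within the scatter). Compound 4 is therefore expected to give 0.9 mL/min, most likely between 0.5 mL/min and 1.6 mL/min.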

Compound 4, intrinsic clearance in a liver preparation (reported as CLH), per the amount of preparation that the assay uses: 2.11 mL/min
The estimate for compound 4 lay 2.3-fold (0.37 log units) below the measured number, outside the stated range (above it).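

In this assay, going from 4-fluorophenyl to 4-methoxyphenyl on this core gives a 2.1-fold higher number from compound 2 to compound 4 (0.32 log units; beyond the scatter), a modest step, whereas the same kind of change on the other core could not be told apart from no change at all. Even so, the two steps themselves cannot be separated with confidence: the same change on two cores in this assay, a 1.2-fold lower number (0.09 log units; within the scatter) from compound 3 to compound 1 and a 2.1-fold higher number (0.32 log units; beyond the scatter) from compound 2 to compound 4, 2.5-fold (0.41 log units) apart, within the scatter of two such steps. Within the data shown here, this means that the result does not show that the core changes what the swap does, nor does it show that the swap can be carried safely from one core to another, since only two pairs are available and each rests on a single comparison.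

The compounds shown leave open whether the rise from compound 2 to compound 4 belongs to methoxy specifically or would also appear with another group in the same place, such as an ethoxy chain, a hydroxyl or an amine. They also leave open which of the several differences between the two cores, if any, matters for this swap.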